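Adding a Third Methoxy Group: Notes on Compound 4

The source may report more compounds than this note shows. Statements on the series, on what has been measured and on what is new or still open speak of the compounds shown alone.

Compound 1 `C=C(Br)C(=O)Nc1ccc(C(=O)/C=C/c2ccccc2)cc1` gives 880 nM in a functional assay on L1210 cells (Mus musculus) for antiproliferative activity, with a stated time of 48 h; a lower number here means a stronger inhibitor, a higher number a weaker inhibitor. Compound 2 `C=C(Br)C(=O)Nc1ccc(C(=O)/C=C/c2ccccc2OC)cc1` carries methoxy in place of hydrogen on an aromatic carbon; in this assay compound 2 gives 1700 nM, which is a 1.9-fold higher number from compound 1 to compound 2 (0.29 log units; within the scatter). Compound 3 `C=C(Br)C(=O)Nc1ccc(C(=O)/C=C/c2cc(OC)cc(OC)c2)cc1` gives 2700 nM in this assay; the difference between its core and the core of compound 1 is not broken down here, and the two values on their own show compound 3 at a higher number than compound 1, beyond the scatter. Compound 4 `C=C(Br)C(=O)Nc1ccc(C(=O)/C=C/c2cc(OC)c(OC)c(OC)c2)cc1` is not yet measured. It differs from compound 3 by methoxy in place of hydrogen on an aromatic carbon, the same kind of change as that from compound 1 to compound 2, though the place differs: ortho to two methoxy groups and para to a large group rather than ortho to a large group. Because a 1.9-fold higher number from compound 1 to compound 2 (0.29 log units; within the scatter) stayed within the scatter, a step of similar size is expected, a 1.5-fold higher number from compound 3 to compound 4 (0.17 log units; within the scatter). Compound 4 is therefore estimated at 4000 nM in this assay, expected to fall between 1500 nM and 10000 nM.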

Compound 4, half-maximal inhibitory concentration: 1500 nM
Compound 4: middle estimate off by 2.7-fold (0.43 log units), on the high side; low and high end bracket the measured number.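

In this assay, methoxy in place of hydrogen on an aromatic carbon gives a 1.8-fold lower number from compound 3 to compound 4 (0.26 log units; within the scatter), and beside the earlier step the change does not carry over as one fixed shift from core to core: the same change on two cores in this assay, a 1.9-fold higher number (0.29 log units; within the scatter) from compound 1 to compound 2 and a 1.8-fold lower number (0.26 log units; within the scatter) from compound 3 to compound 4, 3.5-fold (0.54 log units) apart, beyond the scatter of two such steps. Each step alone stays within the scatter, and only the gap between the two lies beyond it. The pair does not show whether the core or the place accounts for that gap, as the new methoxy sits ortho to two methoxy groups and para to a large group, a place not shared with the earlier step.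

Open, as far as these compounds go, is how an amine or a carboxylic acid at that place would read in this assay. Also open, from the compounds shown here alone, is whether a single methoxy at that place on the core of compound 1 would follow either step.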